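The compounds below may be only part of what the source reports. "The series", "measured", "known", "first", "only" and "open" are said of these compounds alone.

Measured compounds:

compound 1 `C[C@@H](O)CCn1nc2c(Br)c(Br)c(Br)c(Br)c2n1` gives 64% in a functional assay on MCF7 cells (Homo sapiens) for antiproliferative activity, read by MTT assay, with a stated time of 48 h, tested at 50 uM; a higher number here means a weaker effect of the compound at the concentration tested, a lower number a stronger effect
compound 2 `C[C@H](O)CCn1nc2c(Br)c(Br)c(Br)c(Br)c2n1` gives 87% in this assay
compound 3 `CC(O)CCn1nc2c(Br)c(Br)c(Br)c(Br)c2n1` gives 76% in this assay

All three share the same core and the same chain; they differ only in how the stereocentre on that chain is drawn. Compound 3, drawn without a configuration, stands second highest of the three numbers: a number 11 percentage points lower from compound 2 to compound 3 (beyond the scatter) and a number 12 percentage points higher from compound 1 to compound 3 (beyond the scatter), so compound 3 sits between compound 2 and compound 1, closer to compound 2. The largest measured step is a number 23 percentage points higher from compound 1 to compound 2 (beyond the scatter), which rests on the fact that compounds 1 and 2 differ only in the configuration as drawn alone.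

Compound 4 `OCC(O)Cn1nc2c(Br)c(Br)c(Br)c(Br)c2n1` is not yet measured. Its change from compound 3 is 1,2-dihydroxyethyl in place of 2-hydroxypropyl on a saturated chain carbon bound to an aromatic nitrogen. This is a change in the atoms of the chain, not in configuration. Within the data shown here, none of the measured steps bears on it: each of them, by the fact that compounds 1 and 2 differ only in the configuration as drawn, the fact that one of compounds 1 and 3 is drawn with a defined configuration and the other without, at the place where they differ and (the fact that one of compounds 2 and 3 is drawn with a defined configuration and the other without, at the place where they differ), concerns only how the stereocentre is drawn. The three measured numbers all lie in the upper part of the scale, and the measured steps between them were modest. Among the measured compounds shown here, with no step to guide the direction, compound 4 is expected to give 78%, with a range from 58% to 98%, so that the expected step of a number 2 percentage points higher from compound 3 to compound 4 (within the scatter) is not beyond the scatter.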

Compound 4, a percentage reported as activity, at one concentration (the size of the read-out at that concentration, not a potency): 109%
For compound 4 the middle estimate is 31 percentage points below the measured one; measured number outside the range, above it.
By their numbers in this assay, from the lowest: compound 1; then compound 3; then compound 2; then compound 4.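

Replacing 2-hydroxypropyl with 1,2-dihydroxyethyl on a saturated chain carbon bound to an aromatic nitrogen shows that the atoms of this chain, and not only how its stereocentre is drawn, shape the result: in this assay the replacement gives a number 33 percentage points higher from compound 3 to compound 4 (beyond the scatter) and, with both compounds drawn without a configuration, this step belongs to the chain alone. The steps of a number 22 percentage points higher from compound 2 to compound 4 (beyond the scatter) and a number 45 percentage points higher from compound 1 to compound 4 (beyond the scatter) point the same way, although each also has a drawn configuration on one side only. Compound 4 at 109% thus shows the weakest effect of the four at the concentration tested, and nothing known about these compounds explains why.

The compounds shown leave open whether the two drawn configurations of 1,2-dihydroxyethyl would differ from each other, as those of compound 1 and compound 2 do. They also leave open how an amine, a carboxylic acid or a longer chain would read out at this place on the shared core.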